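Removing the Nitro Group from Furyl and Pyrrolyl Enones

This account rests on a few compounds, and the source may have more. Where it says the series, first, only, none or still open, it means among the compounds named here.

Of the compounds shown here, three have been measured in a functional assay on MOLT-4 cells (Homo sapiens) for inhibition, read by MTT assay, with a stated time of 48 h; on this read-out higher numbers stand for weaker inhibition and lower numbers for stronger inhibition. Compound 2 `O=C(/C=C/c1cccc([N+](=O)[O-])c1)c1ccc[nH]1` gives 22000 nM, and compound 3 `O=C(/C=C/c1cccc([N+](=O)[O-])c1)c1ccco1` gives 18000 nM. Compound 1 `O=C(/C=C/c1ccccc1)c1ccc[nH]1` returns only a limit, > 100000 nM, which is the limit of > 100000 nM in this assay, at which 1 of the 3 values shown sits. The change hydrogen in place of nitro on an aromatic carbon brings an at least 4.5-fold higher number from compound 2 to compound 1 (0.65 log units; beyond the scatter). The two cores differ by furan-2-yl in place of 1H-pyrrol-2-yl on a carbonyl carbon, a change that gives a 1.2-fold lower number from compound 2 to compound 3 (0.09 log units; within the scatter). Compound 4 `O=C(/C=C/c1ccccc1)c1ccco1` is not yet measured; it differs from compound 3 by hydrogen in place of nitro on an aromatic carbon, the same change as that between compound 2 and compound 1. Since the measured removal of the nitro group gave an at least 4.5-fold higher number from compound 2 to compound 1 (0.65 log units; beyond the scatter), the step of a 5.6-fold higher number from compound 3 to compound 4 (0.74 log units; beyond the scatter) is expected. Compound 4 is thus expected to give 100000 nM, within a range from 40000 nM to 300000 nM, and its value may again be reported only as a limit.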

Compound 4, half-maximal inhibitory concentration: > 100000 nM
Compound 4 was reported as a limit; the forecaster's own chance of this, stated with the estimate: 60%; the middle value sits exactly at the limit.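

In this assay, going by these compounds, hydrogen in place of nitro again brings an at least 5.5-fold higher number from compound 3 to compound 4 (0.74 log units; beyond the scatter), so the change goes the same way on both cores: the same change on two cores in this assay, an at least 4.5-fold higher number (0.65 log units; beyond the scatter) from compound 2 to compound 1 and an at least 5.5-fold higher number (0.74 log units; beyond the scatter) from compound 3 to compound 4; the limit leaves it open whether they differ Both steps rest on limits, so their true sizes are unknown and the data do not show whether the change is equally large on the two cores: the limit of > 100000 nM in this assay, at which 2 of the 4 values shown sit. The step between compound 1 and compound 4 cannot be read, as both values are limits.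

The compounds shown leave open whether another group at that place, such as an amine or a nitrile, would keep the number near that of compound 3. They also leave open how the two cores compare once the nitro group is gone.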